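Trifluoromethyl removal in a small styryl enone series

A few compounds are considered here, and "the series" means these few. Any claim that something is new, unique, unknown or untested is made for them only; others in the source may bear on it.

Values in a functional assay on HepG2 cells (Homo sapiens) for antiproliferative activity, read by MTT assay, with a stated time of 48 h; on this read-out higher numbers stand for weaker inhibition and lower numbers for stronger inhibition:
- compound 1 `CCCCCCCCCCCCOc1ccc(C(=O)/C=C/c2c(/C=C/c3ccc(OC)cc3)cc(OC)cc2OC)cc1`: 11.6 ug/mL
- compound 2 `COc1ccc(/C=C/c2cc(OC)cc(OC)c2/C=C/C(=O)c2ccc(Br)cc2)cc1`: 12.9 ug/mL
- compound 3 `COc1ccc(/C=C/c2cc(OC)cc(OC)c2/C=C/C(=O)c2ccc(C(F)(F)F)cc2)cc1`: 18.7 ug/mL

Compound 3, at 18.7 ug/mL, lies within the scatter of both compound 2 and compound 1, so these values do not separate the three compounds.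

The next compound to be measured is compound 4 `COc1ccc(/C=C/c2cc(OC)cc(OC)c2/C=C/C(=O)c2ccccc2)cc1`. Its difference from compound 3 is hydrogen in place of trifluoromethyl on an aromatic carbon.

Within the data shown here, the one measured step that bears directly on this change is a 1.4-fold higher number from compound 2 to compound 3 (0.16 log units; within the scatter), which also exchanges the group on that aromatic carbon and stays within the scatter. Compound 1 also carries a different group there, and its value is within the scatter of compound 3. However, no measured compound has hydrogen at this carbon, so the evidence is indirect and the range must stay wide.

No step beyond the scatter is therefore expected in this assay, and the expected step is a 1.2-fold lower number from compound 3 to compound 4 (0.10 log units; within the scatter). The estimated value for compound 4 is 15 ug/mL, with an expected range of 7.5 ug/mL to 30 ug/mL.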

Compound 4, half-maximal inhibitory concentration: 6.8 ug/mL
Beside the measured number, compound 4's estimate is 2.2-fold (0.34 log units) above it; the measured number lies below the stated range.
By their numbers in this assay, from the lowest: compounds 4, 1, 2 and 3 (each within the scatter of the next, the first and the last beyond it).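

In this assay this position now gives its first step beyond the scatter: going from 4-(trifluoromethyl)phenyl to phenyl produces a 2.8-fold lower number from compound 3 to compound 4 (0.44 log units; beyond the scatter), a modest step. The exchange of bromo for hydrogen on the same aromatic carbon gives a 1.9-fold lower number from compound 2 to compound 4 (0.28 log units; within the scatter), which stays within the scatter, and since compound 2 also lies within the scatter of compound 3, only the trifluoromethyl and hydrogen ends of this set are separated. The earlier compounds could not show that the group on this carbon matters at all, while compound 3 and compound 4 now show that it can, although no measurement at hand explains the step.

From the compounds shown here alone, with only hydrogen, bromo and trifluoromethyl compared directly on the shared core, it remains open whether an amine or a carboxylic acid on this carbon would stay with compound 4 or with compound 3, or fall outside both. Going by these compounds, it also remains open whether the separation between compound 3 and compound 4 would hold in any read-out other than this assay.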